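Removing the methoxy: what to expect for compound 3

The source may report more compounds than this note shows. Statements on the series, on what has been measured and on what is new or still open speak of the compounds shown alone.

Of the compounds shown here, two sharing one core have been tested in an ADME assay on J774 cells (Mus musculus) for cytotoxicity, read by WST assay, with a stated time of 24 h; a lower number here means that less compound is needed, a higher number that more compound is needed for the effect. Compound 1 `CCOC(=O)C1=C(C(=O)OCC)C2CSC(CS1)N2Cc1ccc(Cl)cc1` carries a chloro on an aromatic carbon, and in this assay compound 1 gives > 200000 nM, which is a limit of the assay rather than a number. Compound 2 `CCOC(=O)C1=C(C(=O)OCC)C2CSC(CS1)N2Cc1ccc(OC)cc1` carries a methoxy in place of that chloro, and in this assay compound 2 likewise gives > 200000 nM, again a limit. The step that the two limits leave unreadable from compound 1 to compound 2 therefore cannot be read. Compound 2 thus stands at the limit of > 200000 nM in this assay, at which 2 of the 2 values shown sit, the same place as compound 1.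

Compound 3 `CCOC(=O)C1=C(C(=O)OCC)C2CSC(CS1)N2Cc1ccccc1` differs from compound 2 by hydrogen in place of methoxy on an aromatic carbon. Among the compounds with values here, the only measured step, from chloro to methoxy, is unreadable, so it offers no direction for this change, and both measured values sit at the limit. The expected step is none beyond the scatter, a step that the limit leaves unreadable from compound 2 to compound 3. Compound 3 is estimated at 300000 nM, with a range from 100000 nM to 1000000 nM, and will most probably again be reported only as a limit.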

Compound 3, half-maximal effective concentration: 200000 nM
Compound 3: middle estimate off by 1.5-fold (0.18 log units), on the high side; the measured number falls inside the stated range.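

With hydrogen on the aromatic carbon para to a large group, compound 3 gives 200000 nM in this assay as a plain number. Even so, the change reads only as a number no higher from compound 2 to compound 3 (the limit leaves the size open) and the replacement of chloro by hydrogen reads only as a number no higher from compound 1 to compound 3 (the limit leaves the size open), so neither step has a readable size. The number lies right at the edge of what the other two compounds show, and nothing here separates hydrogen, chloro and methoxy at this position: the limit of > 200000 nM in this assay, at which 2 of the 3 values shown sit.

Going by these compounds, whether any group on this aromatic carbon can bring the number clearly down remains open, for example an amine or a carboxylic acid in place of the hydrogen of compound 3. Also open, on these data alone, is whether a change elsewhere on the shared core, such as a longer chain on the benzyl nitrogen link, would move the number into a range where steps can be read.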